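Swapping an ethyl for an ethoxy on the aryl ring

The source may hold more compounds than are shown below. What is called first, only, known or untested is meant among the compounds shown, and "the series" means these compounds.

Measured compounds:
compound 1 `CCc1ccc(-c2nn3cc(-c4cccc(N)c4)nc3s2)cc1`: 6000 nM
compound 2 `C=C(Br)C(=O)Nc1cccc(-c2cn3nc(-c4ccc(CC)cc4)sc3n2)c1`: 2200 nM

In a functional assay on L1210 cells (Mus musculus) for inhibition, read by cell counting, with a stated time of 2 days (on this read-out lower numbers stand for stronger inhibition and higher numbers for weaker inhibition), compound 1 gives 6000 nM, the highest of the two numbers; the nearest is compound 2 with 2200 nM. Compound 3 `CCOc1ccc(-c2nn3cc(-c4cccc(N)c4)nc3s2)cc1` differs from compound 1 by ethoxy in place of ethyl on an aromatic carbon. Among the measured compounds shown here, the only measured step, a 2.7-fold lower number from compound 1 to compound 2 (0.44 log units; beyond the scatter), alters a different part of the shared core, the amine nitrogen, and so says little about an ethoxy replacing an ethyl. For the measured compounds named here, with no step bearing on this change, no shift beyond the scatter is expected in this assay. Compound 3 is therefore estimated at 6000 nM, within 2000 nM to 18000 nM, meaning an expected step of no change at the digits printed from compound 1 to compound 3 (within the scatter).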

Compound 3, half-maximal inhibitory concentration: 155000 nM
The estimate for compound 3 lay 26-fold (1.41 log units) below the measured number; measured number above the stated range.
By their numbers in this assay, from the lowest: compound 2; then compound 1; then compound 3.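

In this assay, this place on the aromatic ring proves sensitive to a small change: ethoxy in place of ethyl gives a 26-fold higher number from compound 1 to compound 3 (1.41 log units; beyond the scatter) and so weakens inhibition. The earlier step changed only the amine nitrogen, so it could not show that the ring substituent also matters, or that this step would be classed as large. Nothing measured here explains why the oxygen-containing group behaves so differently. Going by these compounds, whether a propyl chain, a methoxy or an amine at this place would stay near compound 1 or fall toward compound 3 remains open. Also open, on these data alone, is how the (1-bromoethenyl)carbonyl group on the nitrogen would act alongside ethoxy.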